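Swapping Fluoro for Bromo in a Cell Toxicity Check

This account rests on a few compounds, and the source may have more. Where it says the series, first, only, none or still open, it means among the compounds named here.

Three amides built on one shared core have been examined in an ADME assay on THP-1 cells (Homo sapiens) for cytotoxicity, read by WST assay, with a stated time of 24 h; a higher number here means a weaker inhibitor, a lower number a stronger inhibitor. Compound 1 `COc1cccc(NC(=O)c2ccc3cccc(O)c3n2)c1` gives only a limit of the assay, > 30000 nM. Compound 2 `COc1ccc(NC(=O)c2ccc3cccc(O)c3n2)cc1` likewise returns a limit, > 30000 nM. Compound 3 `O=C(Nc1ccccc1F)c1ccc2cccc(O)c2n1` also sits at a limit, > 30000 nM. All three rest on the same boundary, (the limit of > 30000 nM in this assay, at which 3 of the 3 values shown sit), so the numbers shown do not separate compound 3 from the others. Compound 4 `O=C(Nc1ccccc1Br)c1ccc2cccc(O)c2n1` is not yet measured; it differs from compound 3 by bromo in place of fluoro on an aromatic carbon. Going by the values given here, no measured pair of neighbours offers a step to lean on, so no shift beyond the scatter is expected, and the most likely outcome is that this assay again reports a limit. The expected step is a number no higher from compound 3 to compound 4 (the limit leaves the size open). Compound 4 is therefore expected at 30000 nM, with a range from 10000 nM to 100000 nM.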

Compound 4, half-maximal inhibitory concentration: > 30000 nM
Compound 4: only a limit was reported (the forecaster's own chance of this, stated with the estimate: 75%); the middle value lies on the limit itself.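

Compound 3 and compound 4 both rest on a limit, so no step between them can be read, because every value shown sits on the same boundary: the limit of > 30000 nM in this assay, at which 4 of the 4 values shown sit.

In this assay the compounds shown leave open whether fluoro and bromo differ at all.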